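Aryl exchange on the ring nitrogen and expected cytotoxicity

The source may report more compounds than this note shows. Statements on the series, on what has been measured and on what is new or still open speak of the compounds shown alone.

Measured compounds:
compound 1, `N#Cc1ccc(-n2nc(-c3ccc(C(F)(F)F)cc3O)nc2-c2ccccc2O)cc1`: 66.6%
compound 2, `Oc1cc(C(F)(F)F)ccc1-c1nc(-c2ccccc2O)n(-c2cccc(Cl)c2)n1`: 72.3%

Compound 1, `N#Cc1ccc(-n2nc(-c3ccc(C(F)(F)F)cc3O)nc2-c2ccccc2O)cc1`, in a functional assay on PC-12 cells (Rattus norvegicus) for cytotoxicity, read by MTT assay, with stated times of 2 h and 24 h, tested at 1 uM (a lower number here means a weaker effect, a higher number a stronger effect of the compound at the concentration tested), gives 66.6%. Compound 2, `Oc1cc(C(F)(F)F)ccc1-c1nc(-c2ccccc2O)n(-c2cccc(Cl)c2)n1`, in this assay gives 72.3%. Among the compounds with values here, the one step between them, a number 5.7 percentage points higher from compound 1 to compound 2 (within the scatter), comes from a 3-chlorophenyl in place of 4-cyanophenyl on an aromatic nitrogen. Within the data shown here, compound 2 therefore holds the higher of the two numbers, but its only neighbour, compound 1, sits within the scatter of it, so the two cannot be ordered.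

Compound 3, `Oc1cc(C(F)(F)F)ccc1-c1nc(-c2ccccc2O)n(-c2ccc(Cl)cc2Cl)n1`, is not yet measured. Its change from compound 2 is 2,4-dichlorophenyl in place of 3-chlorophenyl on an aromatic nitrogen. Among the measured compounds shown here, the only measured step that bears on this change is the one from compound 1 to compound 2, which also exchanged the aryl group on that aromatic nitrogen and stayed within the scatter. For the measured compounds named here, no measured pair shows a second chlorine entering on that ring. The expected step is therefore a number 0.3 percentage points lower from compound 2 to compound 3 (within the scatter), none beyond the scatter. Compound 3 is estimated at 72%, with a range from 58% to 86%.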

Compound 3, a percentage reported as activity, at one concentration (the size of the read-out at that concentration, not a potency): 69%
Compound 3: middle estimate off by 3 percentage points, on the high side; low and high end bracket the measured number.
By their numbers in this assay, from the lowest: compounds 1, 3 and 2 (each within the scatter of the next).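

Within the data shown here, compound 3 is the first case here in which a chlorine-bearing aryl group on the aromatic nitrogen gives way to another: in this assay, 2,4-dichlorophenyl in place of 3-chlorophenyl gives a number 3.3 percentage points lower from compound 2 to compound 3 (within the scatter) even though the chlorine count changes and the chlorine pattern on that ring is different. Against the nitrile-bearing aryl group, the same 2,4-dichlorophenyl gives a number 2.4 percentage points higher from compound 1 to compound 3 (within the scatter) and so, with all three steps at this position inside the scatter, 4-cyanophenyl, 3-chlorophenyl and 2,4-dichlorophenyl cannot be told apart in this read-out. Nothing shown here gives a measured explanation for this flat picture, so no cause can be assigned to it.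

The compounds leave open whether any group on this aromatic nitrogen can move the number beyond the scatter, for instance a plain phenyl, a phenyl carrying an amine or a carboxylic acid, or a longer alkyl chain in place of the aryl ring. They also leave open what the two hydroxyphenyl groups and the trifluoromethyl group contribute, as these stay the same in all three compounds.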